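A few compounds are considered here, and "the series" means these few. Any claim that something is new, unique, unknown or untested is made for them only; others in the source may bear on it.

Three aryl variants of the shared core have been tested so far. In a functional assay on MDA-MB-231 cells (Homo sapiens) for cytotoxicity, read by MTT assay, with a stated time of 48 h (on this read-out higher numbers stand for weaker inhibition and lower numbers for stronger inhibition), compound 1 `O=C(NCCCCC(c1ccc(F)cc1)c1ccc(F)cc1)Nc1ccc(I)cc1` gives 11800 nM and compound 2 `O=C(NCCCCC(c1ccc(F)cc1)c1ccc(F)cc1)Nc1ccc([N+](=O)[O-])cc1` gives 6470 nM, and the step between them is small: a 1.8-fold lower number from compound 1 to compound 2 (0.26 log units; within the scatter). Compound 3 `CC(=O)Nc1ccc(NC(=O)NCCCCC(c2ccc(F)cc2)c2ccc(F)cc2)cc1` reads > 20000 nM, which is a limit of the assay and not a number. Its standing therefore rests on that limit alone: the limit of > 20000 nM in this assay, at which 1 of the 3 values shown sits.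

Compound 4 `O=C(NCCCCC(c1ccc(F)cc1)c1ccc(F)cc1)Nc1cccc(Cl)c1` differs from compound 3 as follows: 3-chlorophenyl in place of 4-acetamidophenyl on an amide-type nitrogen. In short, 3-chlorophenyl stands in place of 4-acetamidophenyl on an amide-type nitrogen.

Among the measured compounds shown here, two measured steps bear on this change, since both lead into the acetamido group: an at least 1.6-fold higher number from compound 1 to compound 3 (0.22 log units; that floor lies within the scatter), and an at least 3.0-fold higher number from compound 2 to compound 3 (0.49 log units; beyond the scatter). Leaving that group should therefore lower the number in this assay, although only the second step clears the scatter. Compound 4 is expected to fall near the aryl variant compound 1, at 11800 nM, and not to match the nitro variant exactly. The expected change is an at least 2.2-fold lower number from compound 3 to compound 4 (0.34 log units; beyond the scatter). For compound 4 the estimate is 9000 nM, with an expected range of 4000 nM to 18000 nM.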

Compound 4, half-maximal inhibitory concentration: 5070 nM
Compound 4: the middle estimate sits 1.8-fold (0.25 log units) above what was measured; the measured number falls inside the stated range.
By their numbers in this assay, from the lowest: compounds 4, 2 and 1 (each within the scatter of the next, the first and the last beyond it). At a limit, above all of these: compound 3.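

In this assay, 3-chlorophenyl on the amide-type nitrogen separates from 4-iodophenyl, with a 2.3-fold lower number from compound 1 to compound 4 (0.37 log units; beyond the scatter), while compound 4 cannot be told apart from the 4-nitrophenyl variant, with a 1.3-fold lower number from compound 2 to compound 4 (0.11 log units; within the scatter). Replacing 4-acetamidophenyl gives an at least 3.9-fold lower number from compound 3 to compound 4 (0.59 log units; beyond the scatter), so compound 4 joins compound 2 in a step out of that group that clears the scatter. Compound 3 stays a limit of the assay and not a number, so this step gives only a floor: the limit of > 20000 nM in this assay, at which 1 of the 4 values shown sits.

Compound 4 changes both the halogen and its place on the ring, so 4-chlorophenyl and 3-iodophenyl are the groups that would separate these two changes. Also open, going by these compounds, is how an amine or a carboxylic acid on the aryl ring would read, and whether the aryl trend holds with a shorter chain.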